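Three Cytotoxicity Limits and One Expected Fourth

This account rests on a few compounds, and the source may have more. Where it says the series, first, only, none or still open, it means among the compounds named here.

The study compares three measured compounds and one still awaiting measurement in an ADME assay on Vero cells (Chlorocebus sabaeus) for cytotoxicity, with a stated time of 72 h; a higher number here means a weaker inhibitor, a lower number a stronger inhibitor. Compound 1 `O=[N+]([O-])c1cn2c(n1)OC[C@@H](OCc1ccc(-c3ccc(OC(F)(F)F)cc3)cc1F)C2` reaches only the limit of the assay, giving > 128000 nM in this assay. Compound 2 `O=[N+]([O-])c1cn2c(n1)OC[C@@H](OCc1ccc(-c3ccc(OC(F)(F)F)cc3)cc1C(F)(F)F)C2` likewise reaches only a limit, giving > 128000 nM in this assay. Compound 3 `O=[N+]([O-])c1cn2c(n1)OCC(COc1ccc(-c3ccc(C(F)(F)F)cc3)cc1)C2` also stops at a limit, giving > 128000 nM in this assay. Compound 2 and compound 1 differ by fluoro in place of trifluoromethyl on an aromatic carbon, and the step that the two limits leave unreadable from compound 2 to compound 1 cannot be read because of the limit of > 128000 nM in this assay, at which 3 of the 3 values shown sit. The difference between the core of compound 3 and the core of compound 2 is not broken down here. Compound 4 `O=[N+]([O-])c1cn2c(n1)OCC(COc1ccc(-c3ccc(F)cc3)cc1)C2` differs from compound 3 by fluoro in place of trifluoromethyl on an aromatic carbon, the same kind of change as that from compound 2 to compound 1, though here the place is para to a large group rather than ortho to a large group and meta to a 4-(trifluoromethoxy)phenyl group. Compound 4 is expected to sit at the limit again, with a step that the limit leaves unreadable from compound 3 to compound 4, because of the limit of > 128000 nM in this assay, at which 3 of the 3 values shown sit. Compound 4 is therefore estimated at 160000 nM, with a likely range from 60000 nM to 450000 nM.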

Compound 4, half-maximal inhibitory concentration: > 128000 nM
Compound 4: only a limit was reported; the forecaster's own chance of this, stated with the estimate: 85%; the middle value is on the limit's open side.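

In this assay, compound 4 gives only a limit, > 128000 nM. No step from compound 3 to compound 4 can be read, because the values of both are limits: the limit of > 128000 nM in this assay, at which 4 of the 4 values shown sit.

The compounds shown leave open whether fluoro in place of trifluoromethyl changes the result in this assay at all, and how far each compound lies from its limit.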